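The source may hold more compounds than are shown below. What is called first, only, known or untested is meant among the compounds shown, and "the series" means these compounds.

Three compounds have so far been measured in a functional assay on A-431 cells (Homo sapiens) for cytotoxicity, read by MTT assay, with a stated time of 24 h; a higher number here means a weaker inhibitor, a lower number a stronger inhibitor:

compound 1 `COc1ccc(/C=C\C(=O)O)c(OCc2cn(-c3ccc(NC(C)=O)cc3)nn2)c1CC=C(C)C` — 23400 nM
compound 2 `COc1ccc(/C=C\C(=O)O)c(OCc2cn(-c3ccc(NC(=O)c4ccccc4)cc3)nn2)c1CC=C(C)C` — 21200 nM
compound 3 `COc1ccc(/C=C\C(=O)O)c(OCc2cn(-c3ccccc3)nn2)c1CC=C(C)C` — 21200 nM

Compound 3 stands level with compound 2 at the digits given, and its number differs from that of compound 1 only by a 1.1-fold lower number from compound 1 to compound 3 (0.04 log units; within the scatter). All three values therefore sit within the scatter of one another, and no one of them can be called stronger or weaker than the others.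

Compound 4 `COc1ccc(/C=C\C(=O)O)c(OCc2cn(-c3ccc(C#N)cc3)nn2)c1CC=C(C)C` is the next compound, not yet measured. It differs from compound 3 by cyano in place of hydrogen on an aromatic carbon. For the measured compounds named here, two measured steps bear on this change, since both concern the same aromatic carbon of the shared core: a 1.1-fold lower number from compound 1 to compound 3 (0.04 log units; within the scatter) and no change at the digits printed from compound 2 to compound 3 (within the scatter). Both were within the scatter, as was a 1.1-fold lower number from compound 1 to compound 2 (0.04 log units; within the scatter), which exchanged one group for another at that same place. Going by the values given here, none of the measured compounds carries a cyano group, so nothing here speaks directly to that substituent; what the data do show is that the substituent at this carbon, whether hydrogen, acetamido or benzamido, left the number unchanged beyond the scatter.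

Compound 4 is therefore expected to fall near its neighbours, at an estimated 21000 nM, with a likely range from 10000 nM to 45000 nM. The estimated step of a 1.0-fold lower number from compound 3 to compound 4 (0.00 log units; within the scatter) is expected to stay within the scatter.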

Compound 4, half-maximal inhibitory concentration: 23000 nM
Compound 4: the middle estimate sits 1.1-fold (0.04 log units) below what was measured; low and high end bracket the measured number.
By their numbers in this assay, from the lowest: compounds 2, 3, 4 and 1 (each within the scatter of the next).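

In this assay, cyano on this aromatic carbon, para to a large group, gives no step beyond the scatter from any of the three earlier compounds: (a 1.1-fold higher number from compound 3 to compound 4 (0.04 log units; within the scatter)), (a 1.1-fold higher number from compound 2 to compound 4 (0.04 log units; within the scatter)) and (a 1.0-fold lower number from compound 1 to compound 4 (0.01 log units; within the scatter)). Until now this place had carried only hydrogen, acetamido or benzamido, so the flat picture rested on two amide groups and their absence; cyano, which has neither a carbonyl nor an amide hydrogen, now extends it to a different kind of group, and the four compounds cannot be told apart in this assay. Nothing available explains why the number stays level across these groups.

The compounds shown therefore leave open whether any group at this carbon can move the number beyond the scatter, or whether this place simply has little bearing on it in this series. As far as these compounds go, what an amine, a carboxylic acid or a longer alkyl chain would do here remains unknown, as does the effect of a change elsewhere on the shared core.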